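From diisopropylamino chain to methylsulfonylpiperidine on the urea nitrogen

This account rests on a few compounds, and the source may have more. Where it says the series, first, only, none or still open, it means among the compounds named here.

Compound 2 `CC(C)N(CCN(C(=O)Nc1ccc(F)c(F)c1)C1CC[C@]2(c3cccc(C#N)c3)CC2C1)C(C)C` is a urea carrying a 3,4-difluorophenyl group, and in a functional assay for antagonist activity at melanin-concentrating hormone receptor 1 (Homo sapiens) (a lower number here means a stronger inhibitor, a higher number a weaker inhibitor), compound 2 gives 2.8 nM. Of the three measured compounds it has the lowest number. Compound 1 `CC(C)N(CCN(C(=O)Nc1cccc(Br)c1)C1CC[C@]2(c3cccc(C#N)c3)CC2C1)C(C)C` gives 5.7 nM, so that a 2.0-fold lower number from compound 1 to compound 2 (0.31 log units; beyond the scatter). Compound 3 `CC(C)N(CCN(C(=O)Nc1ccc(F)c(F)c1)C1CC[C@]2(c3cccc(Br)c3)CC2C1)C(C)C` gives 7.76 nM, and a 2.8-fold higher number from compound 2 to compound 3 (0.44 log units; beyond the scatter). Both measured steps are therefore modest, and both lie beyond the scatter.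

Compound 4 `CS(=O)(=O)N1CCC(CN(C(=O)Nc2ccc(F)c(F)c2)C2CC[C@]3(c4cccc(C#N)c4)CC3C2)CC1` keeps the shared core and the 3,4-difluorophenyl urea of compound 2 but alters the side chain on the urea: 1-(methylsulfonyl)piperidin-4-yl in place of (diisopropylamino)methyl on a saturated chain carbon bound to an amide-type nitrogen. Neither measured step touches this part of the molecule; one changes the aryl group on the urea nitrogen, the other the substituent on the aromatic ring of the core. The data thus give no direct guide for this exchange, which replaces an open chain by a ring bearing a methylsulfonyl group. Because a 2.0-fold lower number from compound 1 to compound 2 (0.31 log units; beyond the scatter) and a 2.8-fold higher number from compound 2 to compound 3 (0.44 log units; beyond the scatter) were both modest, a step of moderate size is expected here, most likely towards a higher number. The expected step is a 5.4-fold higher number from compound 2 to compound 4 (0.73 log units; beyond the scatter). Compound 4 is accordingly estimated to give about 15 nM, with a range from 3 nM to 80 nM.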

Compound 4, inhibition constant: 5.4 nM
Compound 4: the middle estimate sits 2.8-fold (0.44 log units) above what was measured; low and high end bracket the measured number.
By their numbers in this assay, from the lowest: compounds 2, 4, 1 and 3 (each within the scatter of the next, the first and the last beyond it).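

For the compounds shown here, the side chain on the urea, untouched by the earlier steps, now has a measured exchange behind it: a 1.9-fold higher number from compound 2 to compound 4 (0.29 log units; within the scatter) is what accompanies the change from 2-(diisopropylamino)ethyl to (1-(methylsulfonyl)piperidin-4-yl)methyl in this assay with the 3,4-difluorophenyl urea and the rest of the molecule held fixed. For this pair, then, the diisopropylamino group is not needed to keep the number where it stands: an open chain with no ring gives way to a six-membered non-aromatic ring with 1 hetero atom, carrying a methylsulfonyl group, and the two compounds remain within the scatter of each other. Nothing available explains why so different a group leaves the number within the scatter.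

The compounds shown leave open whether the methylsulfonyl group contributes anything of its own, since neither an acetyl group in its place nor a piperidin-4-yl group lacking it appears among them. They also leave open whether the same exchange would hold alongside the 3-bromophenyl urea of compound 1 or the bromo substituent of compound 3, and how a longer chain between the urea and the ring would fare.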